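Moving the hydroxyl on a bis-aryl pyridine

A few compounds are considered here, and "the series" means these few. Any claim that something is new, unique, unknown or untested is made for them only; others in the source may bear on it.

Measured compounds:
compound 1, `Oc1ccc(-c2cc(-c3cccs3)cc(-c3ccc(O)cc3)n2)cc1`: 11700 nM
compound 2, `Oc1ccc(-c2cc(-c3ccsc3)cc(-c3ccc(O)cc3)n2)cc1`: 1770 nM
compound 3, `Oc1ccc(-c2cc(-c3cccnc3)cc(-c3ccccc3O)n2)cc1`: > 50000 nM, a limit of the assay, not a number

In a functional assay on T47D cells (Homo sapiens) for cytotoxicity, read by CCK-8 assay (a lower number here means a stronger inhibitor, a higher number a weaker inhibitor), compound 1 gives 11700 nM and compound 2 gives 1770 nM, a change of a 6.6-fold lower number from compound 1 to compound 2 (0.82 log units; beyond the scatter). Among the compounds with values here, compound 3 stands apart from both: in this assay it gives only a limit, > 50000 nM, the one value among the three that sits at the limit of > 50000 nM in this assay, at which 1 of the 3 values shown sits.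

Compound 4, `Oc1ccc(-c2cc(-c3cccnc3)cc(-c3ccc(O)cc3)n2)cc1`, is not yet measured. It differs from compound 3 in one place, (4-hydroxyphenyl in place of 2-hydroxyphenyl on an aromatic carbon). Within the data shown here, no measured step covers this change, since compound 1 and compound 2 both carry the 4-hydroxyphenyl group already, and they differ from compound 4 only in the group opposite the two phenols. What can be said is that both compounds bearing two 4-hydroxyphenyl groups give a number in this assay, whereas compound 3 does not. On that basis a step of an at least 4.1-fold lower number from compound 3 to compound 4 (0.61 log units; beyond the scatter) is expected, toward a lower number, with wide uncertainty. Compound 4 is therefore estimated at 12000 nM, within a range from 2500 nM to 50000 nM.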

Compound 4, half-maximal inhibitory concentration: 2030 nM
Beside the measured number, compound 4's estimate is 5.9-fold (0.77 log units) above it, and the stated range ends above it.
By their numbers in this assay, from the lowest: compounds 2 and 4 (each within the scatter of the next); then compound 1. At a limit, above all of these: compound 3.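

At the aromatic carbon next to the ring nitrogen, the place of the hydroxyl on the phenyl group matters in this assay, and with pyridin-3-yl kept constant, 4-hydroxyphenyl in place of 2-hydroxyphenyl gives an at least 24-fold lower number from compound 3 to compound 4 (1.39 log units; beyond the scatter). Pyridin-3-yl itself is compatible with a measurable value, as its replacement of thiophen-3-yl gives a 1.1-fold higher number from compound 2 to compound 4 (0.06 log units; within the scatter), while its replacement of thiophen-2-yl gives a 5.8-fold lower number from compound 1 to compound 4 (0.76 log units; beyond the scatter). The value of compound 3 is a limit of the assay, so the size of its step has only a floor: the limit of > 50000 nM in this assay, at which 1 of the 4 values shown sits.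

The compounds shown leave open whether a methoxy group or an amine in place of the hydroxyl on 4-hydroxyphenyl would keep a measurable value. They also leave open whether 2-hydroxyphenyl would reach the same limit alongside thiophen-3-yl or thiophen-2-yl.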